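Quinoline-pyrimidine series: cytotoxicity on canine kidney cells

The source may report more compounds than this note shows. Statements on the series, on what has been measured and on what is new or still open speak of the compounds shown alone.

Measured so far:
compound 1, `CSc1nc(NCCCNc2ccnc3cc(Cl)ccc23)c(C#N)c(-c2ccccc2)n1`, gives 20000 nM
compound 2, `CSc1nc(OCCCNc2ccnc3cc(Cl)ccc23)c(C#N)c(-c2ccccc2)n1`, gives 4000 nM
compound 3, `CSc1nc(NCCCCNc2ccnc3cc(Cl)ccc23)c(C#N)c(-c2cccc([N+](=O)[O-])c2)n1`, gives 20000 nM

In an ADME assay on MDCK cells (Canis lupus familiaris) for cytotoxicity, read by microscopy (a higher number here means that more compound is tolerated, a lower number that less compound is tolerated), compound 3 stands level with compound 1 at the digits shown; together they carry the highest of the three numbers, so these two are the best tolerated. Compound 2 is the one that stands apart, with a lower number than compound 3, and that gap is beyond the scatter. Compound 1 and compound 3 show no change within the scatter of this assay.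

Compound 4, `CSc1nc(NCCCCNc2ccnc3cc(Cl)ccc23)c(C#N)c(-c2ccc(C)cc2)n1`, has not yet been measured in this assay. It differs from compound 3 in one place: 4-methylphenyl in place of 3-nitrophenyl on an aromatic carbon. The change is confined to the aryl group on the shared core; the chain between the core and the quinoline is the same as in compound 3.

Among the measured compounds shown here, no step between measured compounds isolates this kind of change, so the expectation rests on compound 3 alone. Given that compound 1 and compound 3 give the same number, the expected step from compound 3 to compound 4, no change at the digits printed from compound 3 to compound 4 (within the scatter), is none beyond the scatter. Compound 4 is therefore estimated at 20000 nM, within the range 7000 nM to 40000 nM.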

Compound 4, minimum cytotoxic concentration: 20000 nM
Estimate against measurement, compound 4: no gap at the digits printed; measured number inside the range.
By their numbers in this assay, from the lowest: compound 2; then compounds 1, 3 and 4 (each within the scatter of the next).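

Working notes, aryl position: in this assay the exchange of 3-nitrophenyl for 4-methylphenyl, on the aromatic carbon ortho to a cyano group, gives no change at the digits printed from compound 3 to compound 4 (within the scatter) and is the first step in the series that isolates a single change at this position. The group that leaves carries 2 hydrogen-bond acceptors and the group that enters carries 0, so for this one pair the reading does not separate two aryl groups that differ in substituent, in substitution pattern and in acceptor count. Nothing at hand gives a reason for this flat step, and the pair alone cannot show whether it reflects any particular feature of either group.

Still open, from the compounds shown here alone, is whether this position stays as flat with a group of another kind on the aryl ring, such as an amine or a carboxylic acid, since both aryl groups compared here are single-substituted phenyl rings. Among the compounds shown here, also open is whether the same exchange reads the same way with the chain of compound 1 or with a longer chain in place of the one shared by compound 3 and compound 4.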